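Furan for benzofuran on two related nucleoside cores

The compounds below may be only part of what the source reports. "The series", "measured", "known", "first", "only" and "open" are said of these compounds alone.

Measured so far:
Compound 1 `CNc1ncnc2c1c(-c1cc3ccccc3o1)cn2[C@@H]1O[C@H](CO)[C@@H](O)[C@H]1O`: in a functional assay on HCT-116 cells (Homo sapiens), read by MTT assay, with a stated time of 72 h (a lower number here means a stronger inhibitor, a higher number a weaker inhibitor), compound 1 reaches only the limit > 20000 nM.
Compound 2 `CNc1ncnc2c1c(-c1ccco1)cn2[C@@H]1O[C@H](CO)[C@@H](O)[C@H]1O`: in this assay compound 2 gives 230 nM.
Compound 3 `Nc1nc(N)c2c(-c3cc4ccccc4o3)cn([C@@H]3O[C@H](CO)[C@@H](O)[C@H]3O)c2n1`: in this assay compound 3 reaches only the limit > 20000 nM.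

From compound 1 to compound 2 the change is furan-2-yl in place of 1-benzofuran-2-yl on an aromatic carbon, and this gives an at least 86-fold lower number from compound 1 to compound 2 (1.93 log units; beyond the scatter). The step is known only as a lower bound because of the limit of > 20000 nM in this assay, at which 2 of the 3 values shown sit, so its true size is not fixed.

Compound 3 carries a different core; the difference between the two cores is not broken down here. Compound 4 `Nc1nc(N)c2c(-c3ccco3)cn([C@@H]3O[C@H](CO)[C@@H](O)[C@H]3O)c2n1` is not yet measured. It stands to compound 3 as compound 2 stands to compound 1: the change is furan-2-yl in place of 1-benzofuran-2-yl on an aromatic carbon, at the same place word for word, so it is the same change.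

If the core of compound 3 behaves like that of compound 1, a large fall is expected, and an at least 20-fold lower number from compound 3 to compound 4 (1.30 log units; beyond the scatter) is the estimated step. Compound 4 is expected to give about 1000 nM, between 150 nM and 10000 nM. Since compound 3 sits at a limit, a second limit remains possible.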

Compound 4, half-maximal inhibitory concentration: > 20000 nM
Compound 4 gave a limit, no number (the forecaster's own chance of this, stated with the estimate: 25%); middle value at least 20-fold (1.30 log units) from the limit.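

Within the data shown here, compound 3 and compound 4 both sit at a limit and give no number, so no step between them can be read: the limit of > 20000 nM in this assay, at which 3 of the 4 values shown sit.

The compounds shown leave open whether furan-2-yl in place of 1-benzofuran-2-yl changes anything on the core of compound 3, as it does on the core of compound 1.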